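The compounds below may be only part of what the source reports. "The series", "measured", "known", "first", "only" and "open" are said of these compounds alone.

In a functional assay on SGC-7901 cells (Homo sapiens) for antiproliferative activity, read by MTT assay, with a stated time of 24 h (on this read-out higher numbers stand for weaker inhibition and lower numbers for stronger inhibition), compound 1 (`CCCCOc1ccc(C(=O)NNC(=O)c2ccccc2NS(=O)(=O)c2cnc(O)nc2O)cc1`) gives 6890 nM and compound 2 (`Cc1ccc(C(=O)NNC(=O)c2ccccc2NS(=O)(=O)c2cnc(O)nc2O)cc1`) gives 15500 nM while compound 3 (`O=C(NNC(=O)c1ccccc1NS(=O)(=O)c1cnc(O)nc1O)c1ccccc1Cl`) gives 2410 nM as the lowest number of the three. Compound 4 (`O=C(NNC(=O)c1ccccc1NS(=O)(=O)c1cnc(O)nc1O)c1ccccc1F`) is still unmeasured, and it carries fluoro in place of chloro on an aromatic carbon, ortho to a large group (fluoro in place of chloro on an aromatic carbon). Within the data shown here, no measured step exchanges one halogen for another. The nearest evidence is the pair of steps that bring in the 2-chlorophenyl group (a 2.9-fold lower number from compound 1 to compound 3 (0.46 log units; beyond the scatter)) and (a 6.4-fold lower number from compound 2 to compound 3 (0.81 log units; beyond the scatter)), alongside the remaining step (a 2.2-fold higher number from compound 1 to compound 2 (0.35 log units; beyond the scatter)). These steps all alter more of the molecule, so only a small shift toward a higher number, probably within the scatter, is expected in this assay for compound 4. The expected step reads a 1.5-fold higher number from compound 3 to compound 4 (0.16 log units; within the scatter) on this estimate. Compound 4 is estimated at 3500 nM (expected range 1300 nM to 9000 nM).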

Compound 4, half-maximal inhibitory concentration: > 20000 nM
Compound 4 gave a limit, no number; the forecaster's own chance of this, stated with the estimate: 3%; middle value at least 5.7-fold (0.75 log units) from the limit.
By their numbers in this assay, from the lowest: compound 3; then compound 1; then compound 2. At a limit, above all of these: compound 4.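

In this assay, compound 4 gives only a limit, > 20000 nM, and not a number. On an aromatic carbon, ortho to a large group, exchanging one halogen alone proves a large change, an at least 8.2-fold higher number from compound 3 to compound 4 (0.91 log units; beyond the scatter), so the low number of compound 3 depends on chloro and does not carry over to fluoro. The other steps are floors too, an at least 2.9-fold higher number from compound 1 to compound 4 (0.46 log units; beyond the scatter) and an at least 1.2-fold higher number from compound 2 to compound 4 (0.11 log units; that floor lies within the scatter), and only the first clears the scatter. The compounds shown leave open whether bromo or methoxy at this place would behave like chloro or like fluoro. They also leave open what number compound 4 would give.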